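A few compounds are considered here, and "the series" means these few. Any claim that something is new, unique, unknown or untested is made for them only; others in the source may bear on it.

Compound 1 `O=S(=O)(Nc1ccc(-c2nc3ccccc3o2)cc1)c1ccc(Cl)s1` is one of two compounds in this set with a result in hand. In an ADME assay on HEK293 cells (Homo sapiens) for cytotoxicity, read by resazurin assay, with a stated time of 48 h (a higher number here means that more compound is tolerated, a lower number that less compound is tolerated), compound 1 gives > 100000 nM, which is a limit of the assay rather than a number. Compound 1 therefore stands at the limit of > 100000 nM in this assay, at which 1 of the 2 values shown sits. The other measured compound, compound 2 `COc1ccc(S(=O)(=O)Nc2ccc3oc(-c4ccccc4)nc3c2)cc1`, gives 91000 nM in this assay; compound 1 and compound 2 differ in more than one place, and their two values are shown only side by side, without a step drawn between them.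

Compound 3 `COc1cccc(S(=O)(=O)Nc2ccc(-c3nc4ccccc4o3)cc2)c1` has not yet been measured. It differs from compound 1 at a single place: 3-methoxyphenyl in place of 5-chlorothiophen-2-yl on a sulfonyl sulfur. No measured step of this kind exists among the compounds shown, so the expectation rests on the two values above. The change is expected to move the half-maximal cytotoxic concentration little, a step of an at least 1.1-fold lower number from compound 1 to compound 3 (0.04 log units; that floor lies within the scatter) that is expected to remain within the usual scatter. Compound 3 is estimated to give 90000 nM in this assay, with an expected range from 40000 nM to 200000 nM, and it is quite possible that the assay will again report only a limit.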

Compound 3, half-maximal cytotoxic concentration: > 100000 nM
Compound 3 was reported as a limit; the forecaster's own chance of this, stated with the estimate: 45%; middle value at least 1.1-fold (0.04 log units) away from the limit.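

Compound 1 and compound 3 are both reported only as a limit in this assay, so no step between them can be read: the limit of > 100000 nM in this assay, at which 2 of the 3 values shown sit.

The compounds shown leave open how far the half-maximal cytotoxic concentration of either compound lies from that limit, and whether 3-methoxyphenyl in place of 5-chlorothiophen-2-yl on a sulfonyl sulfur changes it at all.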